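Removing the Chlorines from the Benzamide Ring

The compounds below may be only part of what the source reports. "The series", "measured", "known", "first", "only" and "open" are said of these compounds alone.

Among the compounds with values here, compound 3 `Cc1ccc(S(=O)(=O)NCc2ccc(CNC(=O)c3c(Cl)cc(Cl)cc3Cl)cc2)cc1` is one of three compounds measured in an assay on MDA-MB-231 cells for binding affinity to C-X-C chemokine receptor type 4 (Homo sapiens), read by immunofluorescence and microscopy, with stated times of 10 min and 30 min; a lower number here means that less compound is needed, a higher number that more compound is needed for the effect. In this assay compound 3 gives 10 nM, level at the digits printed with compound 2 `Cc1ccc(S(=O)(=O)NCc2ccc(CNC(=O)c3ccc(Cl)cc3)cc2)cc1`, for which compound 2 gives 10 nM. Together these two are the lowest of the three numbers, and compound 1 `COc1ccc(C(=O)NCc2ccc(CNS(=O)(=O)c3ccc(C)cc3)cc2)cc1` stands furthest away, as in this assay compound 1 gives 100 nM. The change from compound 3 to compound 4 `Cc1ccc(S(=O)(=O)NCc2ccc(CNC(=O)c3ccccc3)cc2)cc1` is phenyl in place of 2,4,6-trichlorophenyl on a carbonyl carbon. Two kinds of measured step bear on this. The step of no change at the digits printed from compound 2 to compound 3 (within the scatter) shows that a 2,4,6-trichlorophenyl in place of a 4-chlorophenyl left the number where it was. The step of a 10-fold lower number from compound 1 to compound 2 (1.00 log units; beyond the scatter) and the step of a 10-fold lower number from compound 1 to compound 3 (1.00 log units; beyond the scatter) show that replacing a methoxy by a chloro, or a 4-methoxyphenyl by a 2,4,6-trichlorophenyl, lowered the number. Within the data shown here, compound 4 carries neither a chloro nor a methoxy on that ring, and no measured pair shows a bare phenyl directly. The step of a 3.0-fold higher number from compound 3 to compound 4 (0.48 log units; beyond the scatter) is therefore expected to be upward but modest, between the measured extremes. Compound 4 is estimated at 30 nM, with a range from 10 nM to 100 nM.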

Compound 4, effective concentration (reported as EC, without a stated level of effect): > 1000 nM
Compound 4 gave a limit, no number; the forecaster's own chance of this, stated with the estimate: 5%; middle value at least 33-fold (1.52 log units) from the limit.
By their numbers in this assay, from the lowest: compounds 2 and 3 (each within the scatter of the next); then compound 1. At a limit, above all of these: compound 4.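

Compound 4 gives a limit and not a number in this assay: the limit of > 1000 nM in this assay, at which 1 of the 4 values shown sits. The earlier compounds had shown only that a 4-chlorophenyl and a 2,4,6-trichlorophenyl on this carbonyl carbon could not be told apart, which left it unclear whether the chlorines mattered at all, but with none left there is an at least 100-fold higher number from compound 3 to compound 4 (2.00 log units; beyond the scatter) and an at least 100-fold higher number from compound 2 to compound 4 (2.00 log units; beyond the scatter), so the loss of the last chloro is a large step even though the addition of two more changed nothing at the digits printed. The methoxy group, which had looked like the poor substituent in this small set, also turns out better than hydrogen on that aromatic carbon, with an at least 10-fold higher number from compound 1 to compound 4 (1.00 log units; beyond the scatter), so both substituents shown there stand on the lower side of the bare phenyl.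

The compounds shown leave open whether a fluoro, a methyl or an amine on that aromatic carbon would behave like the chloro or like hydrogen. Going by these compounds, as compound 4 rests on a limit, how far its true number lies beyond that limit also stays open.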